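Dropping a Chloro from a Purine-Type Cytotoxic Agent

This account rests on a few compounds, and the source may have more. Where it says the series, first, only, none or still open, it means among the compounds named here.

Among the compounds with values here, compound 2 `ClCc1cccc(Cn2cnc3nc(Cl)nc(Cl)c32)c1` gives 4780 nM in a functional assay on SNB-75 cells (Homo sapiens) for cytotoxicity, read by sulforhodamine B assay, with a stated time of 48 h (a higher number here means that more compound is tolerated, a lower number that less compound is tolerated), the lowest of the two numbers known so far; compound 1 `Nc1nc(Cl)c2ncn(Cc3ccccc3CCl)c2n1` gives 64600 nM in this assay, a gap beyond the usual scatter. Compound 3 `ClCc1cccc(Cn2cnc3ncnc(Cl)c32)c1` differs from compound 2 in one place: hydrogen in place of chloro on an aromatic carbon. The hydrogen enters on an aromatic carbon between two ring nitrogen atoms, meta to a chloro group. Within the data shown here, no measured pair shows this exact change, so the expected step from compound 2 to compound 3 is a modest rise, a 1.9-fold higher number from compound 2 to compound 3 (0.27 log units; within the scatter), near the edge of the scatter. Compound 3 is therefore estimated at 9000 nM, within 3000 nM to 30000 nM.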

Compound 3, concentration lethal to 50% of the cells: 7940 nM
The estimate for compound 3 lay 1.1-fold (0.05 log units) above the measured number; measured number inside the range.
By their numbers in this assay, from the lowest: compounds 2 and 3 (each within the scatter of the next); then compound 1.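

Replacing chloro with hydrogen on the aromatic carbon between two ring nitrogen atoms gives a 1.7-fold higher number from compound 2 to compound 3 (0.22 log units; within the scatter) in this assay and so does not separate the two compounds. At this position, the chloro group is therefore not needed to keep the number seen for compound 2 in these cells. Nothing measured here gives a reason for this result.

Going by these compounds, whether a methyl or methoxy group at this position would keep that number remains open. So does whether the other chloro group on this ring can be replaced as freely.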